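The source may report more compounds than this note shows. Statements on the series, on what has been measured and on what is new or still open speak of the compounds shown alone.

Measured so far:
compound 1 `Cc1cc(C)n(-c2nc(-c3ccc(NS(C)(=O)=O)cc3)cc(=O)[nH]2)n1`, > 50000 nM
compound 2 `Cc1cc(C)n(-c2nc(-c3ccc(S(C)(=O)=O)cc3)cc(=O)[nH]2)n1`, > 50000 nM
compound 3 `CCc1cc(C)nn1-c1nc(C(F)(F)F)cc(=O)[nH]1`, 108000 nM

In an ADME assay on CHO cells (Cricetulus griseus) for cytotoxicity, read by MTT assay (a lower number here means a stronger inhibitor, a higher number a weaker inhibitor), compound 1 gives only a limit, > 50000 nM. Compound 2 likewise gives only a limit, > 50000 nM. The step that the two limits leave unreadable from compound 1 to compound 2 is accordingly unreadable. For the measured compounds named here, compound 3 is the only compound with a number, 108000 nM; the limit of > 50000 nM in this assay, at which 2 of the 3 values shown sit, marks where the other two sit. Compound 4 `Cc1cc(N)n(-c2nc(C(F)(F)F)cc(=O)[nH]2)n1` differs from compound 3 by amino in place of ethyl on an aromatic carbon. Going by the values given here, no measured step bears on this change, as the single measured step is unreadable. With one number in hand, no movement beyond the scatter is expected, and the step of a 1.1-fold lower number from compound 3 to compound 4 (0.03 log units; within the scatter) is an estimate by default. Compound 4 is expected at 100000 nM, range 40000 nM to 250000 nM, with a fair chance that only a limit is reported.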

Compound 4, half-maximal inhibitory concentration: 120000 nM
Compound 4: middle estimate off by 1.2-fold (0.08 log units), on the low side; the range from low to high includes it.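

In this assay, for the compounds shown here, amino in place of ethyl at this position gives a 1.1-fold higher number from compound 3 to compound 4 (0.05 log units; within the scatter), the first step that can be read. At this position, with trifluoromethyl on the shared core, the exchange leaves the read-out unmoved, even though a hydrogen-bond donor and a hydrogen-bond acceptor enter. The step from compound 1 to compound 2 remains unreadable: the limit of > 50000 nM in this assay, at which 2 of the 4 values shown sit.

Still open, as far as these compounds go, is whether a carboxylic acid or a longer chain at this position would move the number. Also open, from the compounds shown here alone, is whether amino would behave the same way on the core of compound 2.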